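Chloromethyl in place of 4-methylphenyl on a carbonyl carbon

This account rests on a few compounds, and the source may have more. Where it says the series, first, only, none or still open, it means among the compounds named here.

Measured so far in a functional assay on HepG2 cells (Homo sapiens) for cytotoxicity, read by MTT assay, with a stated time of 48 h; on this read-out lower numbers stand for stronger inhibition and higher numbers for weaker inhibition
- compound 1 `CC1=NN(S(=O)(=O)c2ccc(C)cc2)C(c2cc(Br)ccc2O)C1` gives 20800 nM
- compound 2 `CC(=O)Oc1ccccc1C1CC(C)=NN1C(=O)CN1CCC(C(C)=O)CC1` gives 7800 nM
- compound 3 `Cc1ccc(C(=O)N2N=C(c3cc4ccccc4oc3=O)CC2c2ccccc2)cc1` gives 52300 nM

Compound 3 has the highest of these three numbers, and its gaps to the other two lie beyond the scatter. Compound 4 `O=C(CCl)N1N=C(c2cc3ccccc3oc2=O)CC1c1ccccc1` puts chloromethyl in place of 4-methylphenyl on a carbonyl carbon and keeps the rest of compound 3. Within the data shown here, no measured pair differs in one place, so no measured step guides this change. Compound 1 (20800 nM) and compound 2 (7800 nM) both lie lower than compound 3, which leaves a downward move as the likelier direction. In this assay a moderate drop is expected, with the estimate a 2.9-fold lower number from compound 3 to compound 4 (0.46 log units; beyond the scatter) pointing to stronger inhibition. Compound 4 is expected at 18000 nM (estimated range 5000 nM to 55000 nM).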

Compound 4, half-maximal inhibitory concentration: 2980 nM
Compound 4: the middle estimate sits 6.0-fold (0.78 log units) above what was measured; the whole stated range lies above it.
By their numbers in this assay, from the lowest: compound 4; then compound 2; then compound 1; then compound 3.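

In this assay, chloromethyl in place of 4-methylphenyl on a carbonyl carbon gives an 18-fold lower number from compound 3 to compound 4 (1.24 log units; beyond the scatter). This first one-place comparison shows that this position matters strongly for the read-out, and that the aromatic ring of 4-methylphenyl is not needed here for inhibition. No measurement at hand gives a reason for the size of this step. The compounds shown leave open whether the chlorine or the loss of the ring accounts for the change. A plain methyl, a longer carbon chain or an amine on the same carbonyl carbon would help separate the two.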